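This account rests on a few compounds, and the source may have more. Where it says the series, first, only, none or still open, it means among the compounds named here.

Compound 1 `COc1cc2ncnc(N3CCc4ccccc43)c2cc1NC(=O)C=C(C)C`: 6270 nM
Compound 2 `CCC/C=C/C(=O)Nc1cc2c(N3CCc4ccccc43)ncnc2cc1OC`: 2920 nM
Compound 3 `CC(C)=CC(=O)Nc1cc2c(N3CCc4ccccc43)ncnc2cc1O[C@@H]1CCOC1`: 3670 nM

All three values come from a functional assay on A549 cells (Homo sapiens) for antiproliferative activity, read by MTT assay, with a stated time of 72 h; on this read-out lower numbers stand for stronger inhibition and higher numbers for weaker inhibition. The number for compound 3 lies within the usual scatter of both other numbers, even though compound 1 and compound 2 differ from each other by more than that scatter.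

Compound 4 `CCC/C=C/C(=O)Nc1cc2c(N3CCc4ccccc43)ncnc2cc1O[C@@H]1CCOC1` differs from compound 3 in one place: pent-1-en-1-yl in place of 2-methylprop-1-en-1-yl on a carbonyl carbon. In words, pent-1-en-1-yl stands in place of 2-methylprop-1-en-1-yl on a carbonyl carbon. The same exchange has been measured once, in the pair with methyl on the oxygen: a 2.1-fold lower number from compound 1 to compound 2 (0.33 log units; beyond the scatter). That step is modest but beyond the scatter. The other measured step, a 1.7-fold lower number from compound 1 to compound 3 (0.23 log units; within the scatter), is oxolan-3-yl in place of methyl on an oxygen on an aromatic ring, and it stays within the scatter. Compound 3 carries that oxolan-3-yl group, so the exchange would now be made in a different setting, and a single earlier example is thin support. A similar or slightly smaller drop is therefore expected in this assay, and it may not clear the scatter. The expected change is a 1.9-fold lower number from compound 3 to compound 4 (0.29 log units; within the scatter). For compound 4 the estimated value is 1900 nM, with an expected range from 1000 nM to 3600 nM.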

Compound 4, half-maximal inhibitory concentration: 9110 nM
Beside the measured number, compound 4's estimate is 4.8-fold (0.68 log units) below it, and the stated range ends below it.
By their numbers in this assay, from the lowest: compounds 2, 3, 1 and 4 (each within the scatter of the next, the first and the last beyond it).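

On the core with oxolan-3-yl on the oxygen, pent-1-en-1-yl in place of 2-methylprop-1-en-1-yl on the carbonyl carbon goes with a 2.5-fold higher number from compound 3 to compound 4 (0.39 log units; beyond the scatter), so in this assay this exchange has no single direction, and its sign turns with the group on the oxygen: the same change on two cores in this assay, a 2.1-fold lower number (0.33 log units; beyond the scatter) from compound 1 to compound 2 and a 2.5-fold higher number (0.39 log units; beyond the scatter) from compound 3 to compound 4, 5.3-fold (0.73 log units) apart, beyond the scatter of two such steps

The oxygen change also looks different once the chain on the carbonyl is pent-1-en-1-yl, where oxolan-3-yl in place of methyl gives a 3.1-fold higher number from compound 2 to compound 4 (0.49 log units; beyond the scatter), a step that clears the scatter, unlike its counterpart with 2-methylprop-1-en-1-yl: the same change on two cores in this assay, a 1.7-fold lower number (0.23 log units; within the scatter) from compound 1 to compound 3 and a 3.1-fold higher number (0.49 log units; beyond the scatter) from compound 2 to compound 4, 5.3-fold (0.73 log units) apart, beyond the scatter of two such steps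

Among these four compounds the two places therefore do not act independently, and a step seen on one compound cannot simply be carried over to another.

The numbers show that the two places are linked, but they do not show why. On these data alone, it also stays open whether the same reversal would appear with a longer chain on the carbonyl carbon, such as hept-1-en-1-yl, with an amine at the end of that chain, or with oxan-4-yl on the oxygen.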